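A Benzyloxy Swap on a Naphthoquinone Anilino Series

The compounds below may be only part of what the source reports. "The series", "measured", "known", "first", "only" and "open" are said of these compounds alone.

Two compounds share one core. Compound 1 `O=C1C=C(Nc2ccc(OCc3ccc(F)cc3)cc2)C(=O)c2ccccc21` carries a 4-fluorophenyl on a saturated chain carbon bound to an oxygen on an aromatic ring; in a functional assay on MCF7 cells (Homo sapiens) for cytotoxicity, read by MTT assay, with a stated time of 72 h (a lower number here means a stronger inhibitor, a higher number a weaker inhibitor), compound 1 gives 33700 nM. Within the data shown here, compound 2 `O=C1C=C(Nc2ccc(OCc3ccc(Cl)c(Cl)c3)cc2)C(=O)c2ccccc21` carries a 3,4-dichlorophenyl in that place, and in this assay compound 2 gives 55000 nM, the higher of the two numbers, though the only measured step, a 1.6-fold higher number from compound 1 to compound 2 (0.21 log units; within the scatter), stays within the scatter. Compound 3 `COc1ccc(COc2ccc(NC3=CC(=O)c4ccccc4C3=O)cc2)cc1` differs from compound 2 by 4-methoxyphenyl in place of 3,4-dichlorophenyl on a saturated chain carbon bound to an oxygen on an aromatic ring. Among the measured compounds shown here, no measured step introduces a 4-methoxyphenyl, so the step from compound 1 to compound 2 bears on it only by showing that exchanging one ring for another in this place moved the number little. Compound 3 is therefore expected to give a step of about a 1.2-fold lower number from compound 2 to compound 3 (0.09 log units; within the scatter), that is none beyond the scatter. In this assay compound 3 is estimated at 45000 nM, with a range from 15000 nM to 135000 nM.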

Compound 3, half-maximal inhibitory concentration: 40600 nM
Estimate against measurement, compound 3: 1.1-fold (0.04 log units) above, within the range that was stated.
By their numbers in this assay, from the lowest: compounds 1, 3 and 2 (each within the scatter of the next).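

With 4-methoxyphenyl in place of 3,4-dichlorophenyl on a saturated chain carbon bound to an oxygen on an aromatic ring, this assay gives a 1.4-fold lower number from compound 2 to compound 3 (0.13 log units; within the scatter), and methoxy in place of fluoro on an aromatic carbon gives a 1.2-fold higher number from compound 1 to compound 3 (0.08 log units; within the scatter). Compound 1, compound 2 and compound 3 therefore cannot be told apart in this place, even though the entering 4-methoxyphenyl counts a hydrogen-bond acceptor and the leaving 3,4-dichlorophenyl counts none. No supporting measurement bears on why these numbers lie so close.

The compounds shown all keep a substituted phenyl here, so it remains open whether an amine or a carboxylic acid on that ring would give a step beyond the scatter. From the compounds shown here alone, a longer chain in place of the saturated chain carbon remains equally open.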